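A few compounds are considered here, and "the series" means these few. Any claim that something is new, unique, unknown or untested is made for them only; others in the source may bear on it.

Measured in a functional assay on A549 cells (Homo sapiens) for inhibition, read by sulforhodamine B assay, with a stated time of 48 h; on this read-out lower numbers stand for stronger inhibition of growth and higher numbers for weaker inhibition of growth:
- compound 1 `COc1cc(/C=C/C(=O)/C(=C/c2cc(OC)c(OC)c(OC)c2)C(C)=O)cc(OC)c1OC`: 530 nM
- compound 2 `COc1cc(/C=C/C(=O)C(=Cc2ccc(OC)c(OC)c2)C(=O)/C=C/c2ccc(O)c(OC)c2)ccc1O`: 430 nM

Compound 2 gives 430 nM and compound 1 gives 530 nM. These two numbers lie within the usual scatter of each other, so they cannot be ranked, and both sit in the same range of growth inhibition.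

The next compound to consider is compound 3 `COc1cc(/C=C/C(=O)C(=Cc2cccc(F)c2)C(=O)/C=C/c2ccc(O)c(OC)c2)ccc1O`, which has not yet been measured. It differs from compound 2 in one place: 3-fluorophenyl in place of 3,4-dimethoxyphenyl on a double-bonded chain carbon bound to a double-bonded chain carbon. In short, 3-fluorophenyl stands in place of 3,4-dimethoxyphenyl.

Within the data shown here, no measured step shows what this swap does in this assay. The expectation is therefore cautious: a small move toward weaker inhibition, possibly none beyond the scatter. The expected change is a 1.4-fold higher number from compound 2 to compound 3 (0.14 log units; within the scatter). For compound 3 the estimated value is 600 nM, with an expected range of 200 nM to 1800 nM.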

Compound 3, concentration for 50% growth inhibition: 360 nM
Estimate against measurement, compound 3: 1.7-fold (0.22 log units) above, and the stated range covers the measured number.
By their numbers in this assay, from the lowest: compounds 3, 2 and 1 (each within the scatter of the next).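

In this assay, 3-fluorophenyl in place of 3,4-dimethoxyphenyl on a double-bonded chain carbon bound to a double-bonded chain carbon gives a 1.2-fold lower number from compound 2 to compound 3 (0.08 log units; within the scatter), so this position accepts the exchange with no readable loss of growth inhibition. The group shrinks from 10 heavy atoms to 7 and from 2 hydrogen-bond acceptors to 0, which shows that neither methoxy group is required for inhibition in the range seen here. No independent measurement on these compounds accounts for this result.

Still open, as far as these compounds go, is whether the fluorine contributes anything, a question that a plain phenyl or a 3-chlorophenyl group at this position would address. Also open, from the compounds shown here alone, is whether this position accepts something other than a phenyl ring, such as an amine, a carboxylic acid or a longer chain.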